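Swapping a Phenethyl for Methoxyphenyl on an Amide

A few compounds are considered here, and "the series" means these few. Any claim that something is new, unique, unknown or untested is made for them only; others in the source may bear on it.

Compound 1 `O=C(CCc1ccccc1)Nc1c(C(O)(C(F)(F)F)C(F)(F)F)ccc2ccccc12` carries a phenethyl group on the carbonyl carbon of its amide. In an assay on LtK cells with ATP-sensitive inward rectifier potassium channel 11 (Homo sapiens) as the target (a higher number here means that more compound is needed for the effect, a lower number that less compound is needed), compound 1 gives 1750 nM, the highest of the three numbers measured. Compound 2 `N#Cc1cccc(C(=O)Nc2c(C(O)(C(F)(F)F)C(F)(F)F)ccc3ccccc23)c1` gives 12 nM and compound 3 `Cc1ccc(C(=O)Nc2c(C(O)(C(F)(F)F)C(F)(F)F)ccc3ccccc23)cc1` gives 76 nM, so both analogues with a ring on the carbonyl carbon need far less compound. The change to compound 4 `COc1ccc(C(=O)Nc2c(C(O)(C(F)(F)F)C(F)(F)F)ccc3ccccc23)cc1` is 4-methoxyphenyl in place of phenethyl on a carbonyl carbon. Among the compounds with values here, two measured steps bear on it: a 150-fold lower number from compound 1 to compound 2 (2.16 log units; beyond the scatter) and a 23-fold lower number from compound 1 to compound 3 (1.36 log units; beyond the scatter), both large when an aromatic ring replaces the phenethyl group. The 4-methoxyphenyl group is closer in kind to 4-methylphenyl than to 3-cyanophenyl, so a step of about a 19-fold lower number from compound 1 to compound 4 (1.29 log units; beyond the scatter) is expected. Compound 4 is therefore estimated at 90 nM, within 25 nM to 300 nM.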

Compound 4, half-maximal effective concentration: 417 nM
Compound 4: middle estimate off by 4.6-fold (0.67 log units), on the low side; measured number outside the range, above it.
By their numbers in this assay, from the lowest: compound 2; then compound 3; then compound 4; then compound 1.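

Having a ring on the carbonyl carbon does not by itself bring the large drop seen earlier, for a 4.2-fold lower number from compound 1 to compound 4 (0.62 log units; beyond the scatter) is only modest. What sits on the ring matters as well: a 5.5-fold higher number from compound 3 to compound 4 (0.74 log units; beyond the scatter) comes with methoxy in place of methyl on an aromatic carbon, and a 35-fold higher number from compound 2 to compound 4 (1.54 log units; beyond the scatter) comes with 4-methoxyphenyl in place of 3-cyanophenyl. Nothing measured here gives a reason for these steps.

Still open, from the compounds shown here alone, is whether the low number of compound 2 goes with the nitrile itself or with where it sits on the ring, a question a 4-cyanophenyl group on the carbonyl carbon would address. Where a 4-aminophenyl group would fall is open too.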